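Swapping the Amine Substituent on a Shared Core

The compounds below may be only part of what the source reports. "The series", "measured", "known", "first", "only" and "open" are said of these compounds alone.

Compound 1 `Nc1ccccc1NC(=O)/C=C/c1ccc(Cn2cnc3c(Nc4cccc(Cl)c4)nc(Cl)nc32)cc1` was tested in a functional assay on NCI-H460 cells (Homo sapiens) for antiproliferative activity, read by CCK-8 assay, with a stated time of 72 h, tested at 2 uM (on this read-out lower numbers stand for a weaker effect and higher numbers for a stronger effect at the one concentration tested), where compound 1 gives 7.11%, the lowest of the two numbers measured. Compound 2 `COC(CCn1cnc2c(NCc3ccc(C(=O)Nc4ccccc4N)cc3)nc(Cl)nc21)OC` differs from it in several places, and in this assay compound 2 gives 43.7%, a gap beyond the usual scatter. Compound 3 `CC1CCN(c2nc(Cl)nc3c2ncn3Cc2ccc(/C=C/C(=O)Nc3ccccc3N)cc2)CC1` has not yet been measured; it differs from compound 1 by 4-methylpiperidin-1-yl in place of (3-chlorophenyl)amino on an aromatic carbon. Among the measured compounds shown here, no single-place step between measured compounds shows how large such a change can be, so only a small shift is expected, and the step of a number 7.9 percentage points higher from compound 1 to compound 3 (within the scatter) is expected to stay within the scatter. Compound 3 is estimated at 15%, in a range from 0% to 45%.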

Compound 3, a percentage reported as inhibition, at one concentration (the size of the read-out at that concentration, not a potency): 8.24%
Compound 3: middle estimate off by 6.8 percentage points, on the high side; low and high end bracket the measured number.
By their numbers in this assay, from the lowest: compounds 1 and 3 (each within the scatter of the next); then compound 2.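

Among the compounds shown here, the swap of 4-methylpiperidin-1-yl in place of (3-chlorophenyl)amino gives the first single-place step in this set: in this assay, it is a number 1.1 percentage points higher from compound 1 to compound 3 (within the scatter). At this position on the shared core and at this one concentration, the read-out therefore does not separate a six-membered aromatic ring on an amino link from a six-membered non-aromatic ring with 1 hetero atom. Nothing available explains this result. Still open, from the compounds shown here alone, is whether a morpholine ring or a simple amino group at this position would give a different number.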